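From 4-phenylphenyl to 2,6-dimethoxyphenyl on the shared core

The compounds below may be only part of what the source reports. "The series", "measured", "known", "first", "only" and "open" are said of these compounds alone.

In a functional assay on HOS-TE85 cells (Homo sapiens) for inhibition, read by CCK-8 assay, with a stated time of 72 h (a lower number here means a stronger inhibitor, a higher number a weaker inhibitor), compound 3 (`O=C(NCCCCc1ccccc1)c1cccc(C2SCC(=O)N2c2ccc(-c3ccccc3)cc2)c1`) gives > 1000 nM, which is a limit of the assay and not a number. Compound 1 (`CCN1C(=O)CSC1c1cccc(C(=O)NCCCCc2ccccc2)c1`) gives > 1000 nM, also a limit. Only compound 2 (`COc1cc(F)ccc1N1C(=O)CSC1c1cccc(C(=O)NCCCCc2ccccc2)c1`) gives a true number, 71.1 nM. These three differ only in the group on the ring nitrogen, and two large steps, both beyond the scatter, bear on that position: an at least 14-fold lower number from compound 1 to compound 2 (1.14 log units; beyond the scatter) and an at least 14-fold higher number from compound 2 to compound 3 (1.14 log units; beyond the scatter).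

Compound 4 (`COc1cccc(OC)c1N1C(=O)CSC1c1cccc(C(=O)NCCCCc2ccccc2)c1`) replaces the 4-phenylphenyl of compound 3 with 2,6-dimethoxyphenyl: 2,6-dimethoxyphenyl in place of 4-phenylphenyl on an amide-type nitrogen in a ring. Like compound 2, which reaches 71.1 nM, compound 4 carries a single aromatic ring with a methoxy group, so a large move towards a lower number is expected. The expected change is an at least 6.6-fold lower number from compound 3 to compound 4 (0.82 log units; beyond the scatter). Some caution remains, given (the limit of > 1000 nM in this assay, at which 2 of the 3 values shown sit), and a second methoxy group is untested here. For compound 4, the estimated value is 150 nM, with an expected range of 30 nM to 800 nM.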

Compound 4, half-maximal inhibitory concentration: > 1000 nM
Compound 4: only a limit was reported (the forecaster's own chance of this, stated with the estimate: 20%); at least 6.6-fold (0.82 log units) between middle value and limit.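

Exchanging one methoxy-bearing phenyl group for another on this nitrogen is enough to change the result sharply: in this assay, the move to 2,6-dimethoxyphenyl gives an at least 14-fold higher number from compound 2 to compound 4 (1.14 log units; beyond the scatter). A methoxy-bearing phenyl group on this nitrogen therefore does not guarantee a low number, and among the compounds shown only the 4-fluoro-2-methoxyphenyl group of compound 2 gives a true value. The steps from compound 1 and from compound 3 to compound 4 cannot be read, as both ends of each are limits and not numbers, and this position remains only coarsely mapped: the limit of > 1000 nM in this assay, at which 3 of the 4 values shown sit.

Going by these compounds, it remains open whether the fluorine, the methoxy group or their combination accounts for the result of compound 2. A plain phenyl ring or a fluorophenyl group without any methoxy on this nitrogen would help to separate these.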